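A few compounds are considered here, and "the series" means these few. Any claim that something is new, unique, unknown or untested is made for them only; others in the source may bear on it.

In an ADME assay on a cell-free system (plasma, Rattus norvegicus) for protein binding, compound 1 (`CNc1nccc(N2CC[C@H](NC(=O)Nc3ccc(CN(C)C)c(C(F)(F)F)c3)C2)n1`) gives 91%, within the scatter of compound 3 (`CNc1nccc(N2CC[C@H](NC(=O)Nc3cccc(OC)c3)C2)n1`) at 93.9%. Compound 2 (`CCNc1nccc(N2CC[C@H](NC(=O)Nc3ccc(Cl)c(C(F)(F)F)c3)C2)n1`) gives 99.9%, which leaves far less compound free and lies beyond the scatter from compound 1. Compound 4 (`CCN1CCN(Cc2ccc(NC(=O)N[C@H]3CCN(c4ccnc(NC)n4)C3)cc2C(F)(F)F)CC1`) is not yet measured and differs from compound 1 as follows: 4-ethylpiperazin-1-yl in place of dimethylamino on a saturated chain carbon bound to an aromatic carbon. Going by the values given here, no measured pair isolates this kind of change, so the expectation stays loose: a small shift toward more binding in this assay, probably none beyond the scatter. The expected move is a 1.3-fold lower unbound fraction from compound 1 to compound 4 (0.11 log units; within the scatter). For compound 4 the estimated value is 93%, with an expected range from 84% to 97.5%.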

Compound 4, plasma protein binding: 84.2%
Compound 4: the middle estimate sits 2.3-fold (0.35 log units) (unbound fraction) below what was measured; measured number inside the range.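

In this assay, going by these compounds alone, the first single-place step at this position, 4-ethylpiperazin-1-yl in place of dimethylamino, gives a 1.8-fold higher unbound fraction from compound 1 to compound 4 (0.24 log units; within the scatter) and so stays within the scatter. At this level of data, the larger ring-bearing amine on this saturated chain carbon and the smaller dimethylamino group cannot be told apart in binding. Nothing measured on these compounds accounts for the size of this step.

As far as these compounds go, whether a morpholine ring or a carboxylic acid at this place would move binding beyond the scatter stays open. Compound 2 differs from compound 1 in more than one place, so its value cannot be assigned to any single group.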